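Methyl for trifluoromethyl on the aryloxymethyl thiadiazole amide

This account rests on a few compounds, and the source may have more. Where it says the series, first, only, none or still open, it means among the compounds named here.

Compound 2 `O=C(O)CCc1ccc(NC(=O)c2nnc(COc3cccc(C(F)(F)F)c3)s2)cc1` is the weaker of the two measured compounds in a functional assay on CHO cells for agonist activity at Free fatty acid receptor 1 (Homo sapiens), read by FLIPR and calcium flux, tested at 1 uM (on this read-out higher numbers stand for an effect only at larger amounts of compound and lower numbers for an effect already at smaller amounts), where compound 2 gives 3090 nM. For the measured compounds named here, the only neighbour is compound 1 `O=C(O)CCc1ccc(NC(=O)c2nnc(COc3ccc4c(c3)CCC4)s2)cc1`, which in this assay gives 1380 nM; the step from compound 1 to compound 2, a 2.2-fold higher number from compound 1 to compound 2 (0.35 log units; beyond the scatter), came with the exchange of 2,3-dihydro-1H-inden-5-yl for 3-(trifluoromethyl)phenyl on the oxygen of the saturated carbon.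

Compound 3 `Cc1cccc(OCc2nnc(C(=O)Nc3ccc(CCC(=O)O)cc3)s2)c1` is to be measured in this assay. It differs from compound 2 by methyl in place of trifluoromethyl on an aromatic carbon of a six-membered aromatic ring of carbon only, meta to a large group.

Going by the values given here, no measured step covers this exchange. Among the compounds with values here, the single step available, a 2.2-fold higher number from compound 1 to compound 2 (0.35 log units; beyond the scatter), concerns a different part of the ring and shows only that changes to this aryl group move the number modestly. For the step from compound 2 to compound 3 a change within or barely beyond the scatter is therefore expected, in no firm direction, giving a 1.2-fold lower number from compound 2 to compound 3 (0.09 log units; within the scatter). Compound 3 is estimated at 2500 nM, with a range from 900 nM to 7000 nM.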

Compound 3, half-maximal effective concentration: 3260 nM
Compound 3: the middle estimate sits 1.3-fold (0.12 log units) below what was measured; low and high end bracket the measured number.
By their numbers in this assay, from the lowest: compound 1; then compounds 2 and 3 (each within the scatter of the next).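

In this assay, methyl and trifluoromethyl on an aromatic carbon, meta to a large group, cannot be told apart: a 1.1-fold higher number from compound 2 to compound 3 (0.02 log units; within the scatter), so at this place going from four heavy atoms, three of them fluorine, to a single carbon leaves no readable mark on the number. The second new step, a 2.4-fold higher number from compound 1 to compound 3 (0.37 log units; beyond the scatter), is of the same size as a 2.2-fold higher number from compound 1 to compound 2 (0.35 log units; beyond the scatter), and the gap to the 2,3-dihydro-1H-inden-5-yl compound therefore appears with either 3-substituted phenyl group, not with trifluoromethyl alone. No measurement at hand bears on why these numbers fall as they do.

Open, on these data alone, is whether the level seen with methyl and trifluoromethyl holds for groups of another kind at this place, such as a methoxy group, an amine or a nitrile, or for a phenyl ring carrying nothing there. Also open is whether the same group on another aromatic carbon of the ring would read alike, since every substituted phenyl shown here carries its group at this one place.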